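One added methoxy on a weak growth inhibitor

A few compounds are considered here, and "the series" means these few. Any claim that something is new, unique, unknown or untested is made for them only; others in the source may bear on it.

For the measured compounds named here, in a functional assay on A549 cells (Homo sapiens) for inhibition, read by sulforhodamine B assay (a higher number here means a weaker inhibitor of growth, a lower number a stronger inhibitor of growth), compound 2 (`COc1ccc(-c2ccc(-c3ccc(-c4nc5ccccc5[nH]4)cc3)cc2)cc1OC`) gives 7600 nM, the only actual number available in this small set. Compound 1 (`COc1cc(-c2ccc(-c3ccc(-c4nc5cc(C)ccc5[nH]4)cc3)cc2)cc(OC)c1OC`) is reported as < 100 nM, which is a limit of the assay and not a number. Compound 3 (`COc1cc(-c2ccc(-c3ccc(-c4nc5ccccc5[nH]4)cc3)cc2)cc(OC)c1OC`) differs from compound 2 by a single change: methoxy in place of hydrogen on an aromatic carbon, ortho to a methoxy group and meta to a large group. Going by the values given here, no measured step shows what this change does in this assay. The expected direction is towards stronger inhibition of growth, by a step well beyond the scatter, an expectation that rests on compound 1 and its limit of < 100 nM. The estimated change is a 25-fold lower number from compound 2 to compound 3 (1.40 log units; beyond the scatter). Compound 3 is expected at about 300 nM, within an estimated range of 50 nM to 2500 nM.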

Compound 3, concentration for 50% growth inhibition: 2110 nM
The estimate for compound 3 lay 7.0-fold (0.85 log units) below the measured number, and the stated range covers the measured number.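

In this assay, methoxy in place of hydrogen on an aromatic carbon, ortho to a methoxy group, gives a 3.6-fold lower number from compound 2 to compound 3 (0.56 log units; beyond the scatter), so this position does respond to the change, though less than the limit on compound 1 had suggested. The larger step lies at another place: hydrogen in place of methyl on an aromatic carbon gives an at least 21-fold higher number from compound 1 to compound 3 (1.32 log units; beyond the scatter), which shows that the added methoxy alone does not bring compound 3 close to compound 1. That second step rests on a limit and not on a number: the limit of < 100 nM in this assay, at which 1 of the 3 values shown sits.

From the compounds shown here alone, the true size of the methyl step stays open, since compound 1 has no actual number. Also open, going by these compounds, is whether a hydroxyl, an amine or a longer chain such as ethoxy at the position of the added methoxy would move the number further.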